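A few compounds are considered here, and "the series" means these few. Any claim that something is new, unique, unknown or untested is made for them only; others in the source may bear on it.

Working notes on the series built on the core of compound 1 `COc1cc(OC)c2c(c1)C(C(O)c1ccc(OCc3ccccc3)cc1)OC2=O`. In an ADME assay on RAW264.7 cells (Mus musculus) for cytotoxicity, read by MTT assay, with a stated time of 24 h, in the absence of a further agent (on this read-out higher numbers stand for weaker inhibition and lower numbers for stronger inhibition), compound 1 gives > 40000 nM, which is a limit and not a number. Compound 2 `COc1cc(OC)c2c(c1)C(C(O)c1ccc(OCc3ccc(F)cc3)cc1)OC2=O`, which carries (4-fluorobenzyl)oxy, gives > 40000 nM in this assay, again a limit and not a number. Compound 2 therefore has no exact position in the series, and its standing is summed up as the limit of > 40000 nM in this assay, at which 2 of the 2 values shown sit.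

The next structure is compound 3 `COc1cc(OC)c2c(c1)C(C(O)c1ccc(OCc3ccc(C#N)cc3)cc1)OC2=O`, with cyano in place of fluoro on an aromatic carbon, para to a large group: cyano in place of fluoro on an aromatic carbon. Among the measured compounds shown here, the one measured step at this place is a step that the two limits leave unreadable from compound 1 to compound 2, and it has no readable size. With only a step that the two limits leave unreadable from compound 1 to compound 2 to go on, no measured size carries over to compound 3, and no direction can be drawn from it. The estimated a number no higher from compound 2 to compound 3 (the limit leaves the size open) in this assay is therefore expected to stay within the scatter. Compound 3 is estimated at 40000 nM, with an expected range from 20000 nM to 80000 nM.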

Compound 3, half-maximal inhibitory concentration: > 40000 nM
Compound 3 ended at the assay's limit; the forecaster's own chance of this, stated with the estimate: 85%; the middle value sits exactly at the limit.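

In this assay compound 3 gives > 40000 nM, a limit and not a number. No step among compound 1, compound 2 and compound 3 can be read, as all three stand at one value: the limit of > 40000 nM in this assay, at which 3 of the 3 values shown sit.

The compounds shown leave open whether hydrogen, fluoro and cyano at this place differ at all in this assay, and at what concentration any of the three would reach half-maximal inhibition.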